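From acetamido to (phenylsulfonyl)oxy on a saturated ring carbon

A few compounds are considered here, and "the series" means these few. Any claim that something is new, unique, unknown or untested is made for them only; others in the source may bear on it.

In an ADME assay on Vero cells (Chlorocebus sabaeus) for cytotoxicity, read by MTT assay, with a stated time of 48 h (a lower number here means a stronger inhibitor, a higher number a weaker inhibitor), compound 3 `CC(=O)NC1CCC(CN2CCN(c3cc(=O)c4cc(C(F)(F)F)cc([N+](=O)[O-])c4s3)CC2)CC1` gives > 64 ug/mL as a limit of the assay and not a number. Compound 1 `O=C(OC1CCC(CN2CCN(c3cc(=O)c4cc(C(F)(F)F)cc([N+](=O)[O-])c4s3)CC2)CC1)c1ccncc1` gives > 64 ug/mL as a limit as well. Compound 2 `O=C(OC1CCC(CN2CCN(c3cc(=O)c4cc(C(F)(F)F)cc([N+](=O)[O-])c4s3)CC2)CC1)c1ccc2c(c1)OCC2` gives > 64 ug/mL as a limit as well.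

Compound 4 `O=c1cc(N2CCN(CC3CCC(OS(=O)(=O)c4ccccc4)CC3)CC2)sc2c([N+](=O)[O-])cc(C(F)(F)F)cc12` carries (phenylsulfonyl)oxy in place of acetamido on a saturated ring carbon. Within the data shown here, three measured steps bear on this change: a step that the two limits leave unreadable from compound 1 to compound 3 and a step that the two limits leave unreadable from compound 2 to compound 3 and also a step that the two limits leave unreadable from compound 1 to compound 2 among the two esters. None of them has a readable size. Compound 1 and compound 2 also hold an oxygen-linked group on that ring carbon, and no step beyond the scatter is expected because the limit of > 64 ug/mL in this assay, at which 3 of the 3 values shown sit, and no lower number has appeared in this assay for these compounds. The expected change is a number no higher from compound 3 to compound 4 (the limit leaves the size open) (no step beyond the scatter). Compound 4 is estimated at 64 ug/mL with 32 ug/mL to 128 ug/mL as the expected range, and another limit is the likely report.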

Compound 4, half-maximal inhibitory concentration: > 64 ug/mL
Compound 4 was reported as a limit; the forecaster's own chance of this, stated with the estimate: 85%; the middle value lies on the limit itself.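

In this assay, among these compounds, compound 4 gives > 64 ug/mL, a limit of the assay and not a number, so no step between compound 4 and compound 1, compound 2 or compound 3 can be read. The compounds shown leave open whether these groups on the saturated ring carbon differ at all in this assay, and by how much.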